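The source may hold more compounds than are shown below. What is called first, only, known or untested is meant among the compounds shown, and "the series" means these compounds.

The measured compounds in this assay:

Compound 1 `COc1ccccc1NC(=O)NC1CC(C)(C)Oc2ccc(F)cc21`: in a functional assay (aorta) with Rattus norvegicus as the target (a higher number here means that more compound is needed for the effect, a lower number that less compound is needed), compound 1 gives > 10000 nM, which is a limit of the assay and not a number.
Compound 2 `COc1cccc(NC(=O)NC2CC(C)(C)Oc3ccc(F)cc32)c1`: in this assay compound 2 gives > 10000 nM, again a limit of the assay.
Compound 3 `COc1ccc(NC(=O)NC2CC(C)(C)Oc3ccc(F)cc32)cc1`: in this assay compound 3 gives 15500 nM.

Among the measured compounds shown here, compound 3 therefore stands as the only actual number among the three; the other two sit at the limit of > 10000 nM in this assay, at which 2 of the 3 values shown sit. The steps a step that the two limits leave unreadable from compound 1 to compound 2, a step that the limit leaves unreadable from compound 1 to compound 3 and a step that the limit leaves unreadable from compound 2 to compound 3 are all unreadable for this reason. The unmeasured compound 4 `Cc1cccc(NC(=O)NC2CC(C)(C)Oc3ccc(F)cc32)c1` differs from compound 3 in one place: 3-methylphenyl in place of 4-methoxyphenyl on an amide-type nitrogen. For the measured compounds named here, none of the measured steps exchanges a methoxy group for a methyl group; all of them only move the methoxyphenyl group, and none of them yields a readable size. No direction beyond the scatter can therefore be expected, and the estimate simply stays near where compound 3 already lies. The expected step of a 1.0-fold lower number from compound 3 to compound 4 (0.01 log units; within the scatter) is accordingly close to none. Compound 4 is thus estimated at 15000 nM, within a range from 4000 nM to 50000 nM.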

Compound 4, half-maximal effective concentration: > 30000 nM
Compound 4 ended at the assay's limit; the forecaster's own chance of this, stated with the estimate: 55%; middle value at least 2.0-fold (0.30 log units) away from the limit.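

Compound 4 gives > 30000 nM as a limit of the assay and not a number. Even so, 3-methylphenyl in place of 4-methoxyphenyl on the amide-type nitrogen gives an at least 1.9-fold higher number from compound 3 to compound 4 (0.28 log units; that floor lies within the scatter) in this assay as the first step in the series with a readable floor; the true step may be larger, and no fall in the number appears with this change. The steps to compound 4 from compound 1 and from compound 2 join two limits and cannot be read, so methyl in place of methoxy on the aromatic carbon has no size of its own.

Among the compounds shown here, compound 3 remains the only compound with an actual number. From the compounds shown here alone, whether an amine or a carboxylic acid in place of the methyl group would bring the number down in this assay stays open.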